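This account rests on a few compounds, and the source may have more. Where it says the series, first, only, none or still open, it means among the compounds named here.

Of the compounds shown here, two have been measured in a functional assay on MOLT-4 cells (Homo sapiens) for inhibition, read by sulforhodamine B assay, with a stated time of 48 h, tested at 10 uM; on this read-out higher numbers stand for more inhibition at the one concentration tested (going by the name of the read-out) and lower numbers for less inhibition. Compound 1 `c1ccc2c(-c3cn4ccnc4c(-c4ccc5ncn(C6CCCCC6)c5c4)n3)cccc2c1` gives 44.7%, and compound 2 `Brc1ccc(-c2cn3ccnc3c(-c3ccc4ncn(C5CCCCC5)c4c3)n2)cc1` gives 20.4%. Among the measured compounds shown here, the only one-place step seen so far is a number 24.3 percentage points lower from compound 1 to compound 2 (beyond the scatter). Compound 2 therefore stands lowest of the two numbers, with compound 1 above it by a gap beyond the scatter.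

Compound 3 `Fc1ccccc1-c1cn2ccnc2c(-c2ccc3ncn(C4CCCCC4)c3c2)n1` follows from compound 2 by a single change: 2-fluorophenyl in place of 4-bromophenyl on an aromatic carbon. The step from compound 1 to compound 2 bears on it only indirectly, since it exchanged naphthalen-1-yl for 4-bromophenyl at the same aromatic carbon and was of modest size. For the measured compounds named here, no measured step exchanges one substituted phenyl for another at this position, so the direction of the present change is not fixed by the data. Some recovery toward the level of compound 1 is plausible but uncertain. A step of a number 9.6 percentage points higher from compound 2 to compound 3 (within the scatter) is expected. Compound 3 is therefore estimated at 30%, with a range from 10% to 55%.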

Compound 3, a percentage reported as inhibition, at one concentration (the size of the read-out at that concentration, not a potency): 22.5%
Beside the measured number, compound 3's estimate is 7.5 percentage points above it, within the range that was stated.
By their numbers in this assay, from the lowest: compounds 2 and 3 (each within the scatter of the next); then compound 1.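

In this assay, 2-fluorophenyl in place of 4-bromophenyl on this aromatic carbon gives a number 2.1 percentage points higher from compound 2 to compound 3 (within the scatter), so this read-out does not separate the two halogen-bearing phenyl groups, even though they differ in both the halogen and its place on the phenyl ring. Against naphthalen-1-yl, the same position gives a number 22.2 percentage points lower from compound 1 to compound 3 (beyond the scatter), so compound 1 stands apart from both phenyl compounds, not only from compound 2. No supporting data on the series account for these numbers.

On these data alone, whether a phenyl group carrying an amine or a carboxylic acid at this carbon would stay with compound 2 and compound 3 or approach compound 1 remains open. The compounds shown also leave open how the cyclohexyl group contributes, since it is the same in all three.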